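This account rests on a few compounds, and the source may have more. Where it says the series, first, only, none or still open, it means among the compounds named here.

Working notes on the series, read in a functional assay on K562 cells (Homo sapiens) for antiproliferative activity, with a stated time of 72 h; a lower number here means a stronger inhibitor, a higher number a weaker inhibitor. Compound 1 `OC[C@H]1O[C@@H](n2cnc3c(NCc4cccc(Br)c4)ncnc32)[C@H](O)[C@@H]1O` gives 19700 nM. Compound 2 `COc1cc(CNc2ncnc3c2ncn3[C@@H]2O[C@H](CO)[C@@H](O)[C@H]2O)cc(OC)c1` gives > 166000 nM, which is a limit of the assay and not a number. Of the two readings in this assay, that limit is the weaker end. The next change leads to compound 3 `OC[C@H]1O[C@@H](n2cnc3c(NCc4ccc(F)cc4F)ncnc32)[C@H](O)[C@@H]1O`: 2,4-difluorophenyl in place of 3,5-dimethoxyphenyl on a saturated chain carbon bound to a nitrogen on an aromatic ring. In words, 2,4-difluorophenyl replaces 3,5-dimethoxyphenyl on a saturated chain carbon bound to a nitrogen on an aromatic ring. Within the data shown here, only one measured step bears on this place: an at least 8.4-fold higher number from compound 1 to compound 2 (0.92 log units; beyond the scatter), where 3,5-dimethoxyphenyl replaced 3-bromophenyl. Leaving 3,5-dimethoxyphenyl is therefore expected to give a lower number, with a step of similar or somewhat smaller size, though one step is thin support. The expected change is an at least 4.1-fold lower number from compound 2 to compound 3 (0.61 log units; beyond the scatter). Compound 3 is estimated at 40000 nM, with an expected range of 12000 nM to 150000 nM.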

Compound 3, half-maximal inhibitory concentration: 9600 nM
Compound 3: the middle estimate sits 4.2-fold (0.62 log units) above what was measured; measured number below the stated range.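

Going from 3-bromophenyl to 2,4-difluorophenyl in this assay gives a 2.1-fold lower number from compound 1 to compound 3 (0.31 log units; beyond the scatter), so this place on a saturated chain carbon bound to a nitrogen on an aromatic ring accepts a second halogen-bearing phenyl, and the reading improves modestly. Leaving 3,5-dimethoxyphenyl for 2,4-difluorophenyl gives an at least 17-fold lower number from compound 2 to compound 3 (1.23 log units; beyond the scatter), which places both halogen-bearing groups on the stronger side of 3,5-dimethoxyphenyl. The size of that step is only a bound, since the reading of compound 2 is a limit and not a number: the limit of > 166000 nM in this assay, at which 1 of the 3 values shown sits.

The compounds shown do not tell whether the difference between compound 1 and compound 3 comes from the kind of halogen, their number or their placement on the ring. Also open, as far as these compounds go, is how a phenyl bearing a single fluorine, or a cyclohexyl or pyridyl group in place of the phenyl, would read at this place.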